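The source may hold more compounds than are shown below. What is called first, only, known or untested is meant among the compounds shown, and "the series" means these compounds.

In a functional assay on HepG2 cells (Homo sapiens) for antiproliferative activity, read by MTT assay, with a stated time of 72 h (a lower number here means a stronger inhibitor, a higher number a weaker inhibitor), compound 1 (`O=C(N/N=C/c1ccccc1)Nc1ccc(Oc2ccnc3[nH]ccc23)c(F)c1`) gives 640 nM and compound 2 (`O=C(N/N=C/c1ccc(O)c(Br)c1)Nc1ccc(Oc2ccnc3[nH]ccc23)c(F)c1`) gives 1360 nM while compound 3 (`O=C(N/N=C/c1ccccc1)Nc1ccc(Oc2ccnc3[nH]ccc23)cc1`) gives 750 nM as its value. Compound 3 therefore stands within the scatter of both other compounds, even though those two lie beyond the scatter of each other.

The next compound, compound 4 (`O=C(N/N=C/c1ccc(F)cc1)Nc1ccc(Oc2ccnc3[nH]ccc23)cc1`), differs from compound 3 at one spot, where phenyl becomes 4-fluorophenyl. The change is fluoro in place of hydrogen on an aromatic carbon and in words it is fluoro in place of hydrogen on an aromatic carbon, para to a large group.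

Within the data shown here, two measured steps bear on this. Putting hydrogen in place of fluoro on a different aromatic ring gave a 1.2-fold higher number from compound 1 to compound 3 (0.07 log units; within the scatter) and so a swap of these same two atoms has not yet moved the number measurably. Replacing the phenyl itself gave a 2.1-fold higher number from compound 1 to compound 2 (0.33 log units; beyond the scatter) but that replacement, 3-bromo-4-hydroxyphenyl, is a much bigger alteration than a lone fluoro, and its step is only modest.

No step beyond the scatter is therefore expected in this assay for this change. The expected move is a 1.1-fold higher number from compound 3 to compound 4 (0.03 log units; within the scatter) and this estimate stays small. Compound 4 is expected to lie near 800 nM within an estimated range from 400 nM to 1600 nM as its likely span.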

Compound 4, half-maximal inhibitory concentration: 3430 nM
The estimate for compound 4 lay 4.3-fold (0.63 log units) below the measured number; measured number outside the range, above it.
By their numbers in this assay, from the lowest: compounds 1, 3 and 2 (each within the scatter of the next, the first and the last beyond it); then compound 4.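

In this assay, a single fluoro on the phenyl ring, para to a large group, gives a 4.6-fold higher number from compound 3 to compound 4 (0.66 log units; beyond the scatter), so this ring responds to a change of one atom. The earlier exchange of the same two atoms, made on the other aromatic ring, gave only a 1.2-fold higher number from compound 1 to compound 3 (0.07 log units; within the scatter), which shows that the effect of this swap depends on where it is made. With a 2.1-fold higher number from compound 1 to compound 2 (0.33 log units; beyond the scatter) also on record, both substituted phenyl rings shown here, 3-bromo-4-hydroxyphenyl and 4-fluorophenyl, carry higher numbers than their unsubstituted partners, although these two steps start from different cores; nothing available here explains why this ring is so sensitive.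

Going by these compounds, it remains open whether the loss belongs to fluoro itself or would follow any group at this place, a question that a chloro, a methoxy or an amine in the same position could help settle. On these data alone, it is also open whether 4-fluorophenyl would act in the same way on the core of compound 1, which already carries a fluoro on its other aromatic ring.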